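The compounds below may be only part of what the source reports. "The series", "measured", "known", "first", "only" and "open" are said of these compounds alone.

Measured so far in a functional assay on CHO cells for positive allosteric modulation of muscarinic acetylcholine receptor M5 (Homo sapiens), read by FLIPR and calcium flux, with a stated time of 1 h; a lower number here means a smaller maximal response, a higher number a larger maximal response:
compound 1 `COc1cccc(Oc2ccc(CN3C(=O)C(=O)c4cc(OC(F)(F)F)ccc43)cc2)n1` gives 51%
compound 2 `O=C1C(=O)N(Cc2ccc(-c3ccccc3)cc2F)c2ccc(OC(F)(F)F)cc21` gives 63%
compound 3 `O=C1C(=O)N(Cc2ccc(Oc3nccs3)cc2)c2ccc(OC(F)(F)F)cc21` gives 58%

On the numbers as read, compound 3 is second highest of the three; compound 2 reads higher and compound 1 lower, each gap within the scatter and so not a real difference. Compound 4 `O=C1C(=O)N(Cc2ccc(-c3ccccc3)cc2)c2ccc(OC(F)(F)F)cc21` differs from compound 3 by phenyl in place of (1,3-thiazol-2-yl)oxy on an aromatic carbon. Going by the values given here, the only measured step at this position, a number 7 percentage points higher from compound 1 to compound 3 (within the scatter), exchanged one aryloxy group for another and stayed within the scatter. Among the compounds with values here, no measured step leads to compound 4; compound 2, which also carries a directly attached phenyl, gives 63% in this assay, close to compound 3. The change is therefore expected to move this assay little, a number 2 percentage points higher from compound 3 to compound 4 (within the scatter), with no clear direction. Compound 4 is estimated at 60%, range 48% to 72%.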

Compound 4, largest response reached (Emax), in percent of the reference or control that the assay uses: < 60%
Compound 4: a limit, no number; the forecaster's own chance of this, stated with the estimate: 0%; the middle value lies on the limit itself.
By their numbers in this assay, from the lowest: compounds 1, 3 and 2 (each within the scatter of the next, the first and the last beyond it).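

In this assay compound 4 gives < 60%, which is a limit of the assay and not a number. Hydrogen in place of fluoro on an aromatic carbon gives a number at least 3 percentage points lower from compound 2 to compound 4 (that floor lies within the scatter), so this first fluoro-to-hydrogen comparison in the series fixes only a floor for the step, not its size. The steps from compound 3 and from compound 1 to compound 4 cannot be read: the limit of < 60% in this assay, at which 1 of the 4 values shown sits.

Going by these compounds, whether phenyl and aryloxy groups differ at this aromatic carbon stays open. So does how an amine or a longer alkyl chain there would read in this assay.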